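From benzyloxy to isopropylamino on a shared core

The source may report more compounds than this note shows. Statements on the series, on what has been measured and on what is new or still open speak of the compounds shown alone.

Measured so far in an ADME assay on J774.A1 cells (Mus musculus) for inhibition, read by MTT assay, with a stated time of 72 h; a higher number here means that more compound is needed for the effect, a lower number that less compound is needed:
- Compound 1 `CC(C)Nc1nc(NCc2ccco2)c2ccccc2n1`: 17000 nM
- Compound 2 `c1ccc(CNc2nc(OCc3ccccc3)c3ccccc3n2)cc1`: 3300 nM
- Compound 3 `CNc1nc(NCc2ccco2)c2ccccc2n1`: "not determined" (no result reported)

Compound 2 holds the lower of the two numbers at 3300 nM, and compound 1 stands higher at 17000 nM, a gap beyond the usual scatter. Compound 4 `CC(C)Nc1nc(NCc2ccccc2)nc2ccccc12` has not yet been measured. It differs from compound 2 by isopropylamino in place of benzyloxy on an aromatic carbon. Going by the values given here, compound 1 also carries isopropylamino and no benzyloxy, and its 17000 nM is the only guide, so a rise is expected. The expected change in this assay is a 2.7-fold higher number from compound 2 to compound 4 (0.44 log units; beyond the scatter), upward and modestly beyond the scatter. For compound 4 the estimated value is 9000 nM, with an expected range of 2800 nM to 30000 nM.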

Compound 4, half-maximal effective concentration: 7200 nM
Estimate against measurement, compound 4: 1.3-fold (0.10 log units) above, and the stated range covers the measured number.
By their numbers in this assay, from the lowest: compound 2; then compound 4; then compound 1.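

In this assay, putting isopropylamino in place of benzyloxy on this aromatic carbon, with the benzylamino group left unchanged, gives a 2.2-fold higher number from compound 2 to compound 4 (0.34 log units; beyond the scatter) and so shows that this position responds to the swap, though modestly. The earlier compounds shown here offered no pair differing in this one place, so this size could not be read from them. Nothing shown here says why the number moves.

Going by these compounds, whether hexylamino, a longer amine chain, or a smaller ether such as methoxy would move the number further in this place remains open.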